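This account rests on a few compounds, and the source may have more. Where it says the series, first, only, none or still open, it means among the compounds named here.

Measured so far in a functional assay on HCT-15 cells (Homo sapiens) for inhibition, read by sulforhodamine B assay, with a stated time of 72 h; a lower number here means a stronger inhibitor, a higher number a weaker inhibitor:
compound 1 `COc1ccc(CN(Cc2ccccc2)Cc2c(O)ccc3c(=O)cc(C)oc23)cc1` gives 10.7 ug/mL
compound 2 `CCN(Cc1ccc(OC)cc1)Cc1c(O)ccc2c(=O)cc(C)oc12` gives 22.5 ug/mL
compound 3 `COc1ccc(CN(Cc2ccc([N+](=O)[O-])cc2)Cc2c(O)ccc3c(=O)cc(C)oc23)cc1` gives 28.6 ug/mL

Compound 3 carries the highest of the three numbers in this assay; its gap to compound 2 lies within the scatter, whereas the step of a 2.7-fold higher number from compound 1 to compound 3 (0.43 log units; beyond the scatter) lies beyond it. Compound 4 `COc1ccc(CN(Cc2ccc3ccccc3c2)Cc2c(O)ccc3c(=O)cc(C)oc23)cc1` is the next member, not yet measured. Its change from compound 3 is naphthalen-2-yl in place of 4-nitrophenyl on a saturated chain carbon bound to an amine nitrogen. Within the data shown here, two measured steps bear on this. The nitro group added in a 2.7-fold higher number from compound 1 to compound 3 (0.43 log units; beyond the scatter) is absent again in compound 4, which on its own would bring the number back toward that of compound 1. The step of a 1.3-fold higher number from compound 2 to compound 3 (0.10 log units; within the scatter) shows that exchanging methyl for 4-nitrophenyl on the saturated chain carbon bound to the amine nitrogen made little difference, so the second ring of naphthalen-2-yl is not expected to shift the number far by itself. A modest decrease, a 2.4-fold lower number from compound 3 to compound 4 (0.38 log units; beyond the scatter), is therefore expected, landing near the number of compound 1. Compound 4 is estimated at 12 ug/mL, with a range from 5 ug/mL to 30 ug/mL.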

Compound 4, half-maximal inhibitory concentration: 6.89 ug/mL
Compound 4: middle estimate off by 1.7-fold (0.24 log units), on the high side; the measured number falls inside the stated range.
By their numbers in this assay, from the lowest: compounds 4 and 1 (each within the scatter of the next); then compounds 2 and 3 (each within the scatter of the next).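

In this assay the saturated chain carbon bound to an amine nitrogen accepts naphthalen-2-yl as readily as phenyl, as a 1.6-fold lower number from compound 1 to compound 4 (0.19 log units; within the scatter) shows, so the second ring brings no readable change there. With a 4.2-fold lower number from compound 3 to compound 4 (0.62 log units; beyond the scatter) and a 3.3-fold lower number from compound 2 to compound 4 (0.51 log units; beyond the scatter) both printed beyond the scatter, compound 4 stands apart from compound 2 and compound 3 just as compound 1 does, grouping the two unsubstituted carbon-only aromatic groups together; compound 3 shows that an aromatic ring alone does not suffice, since its 4-nitrophenyl group stays level with the methyl of compound 2. No measurement here accounts for this grouping.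

Going by these compounds, whether a 4-aminophenyl or 4-chlorophenyl group would side with compound 1 and compound 4 or with compound 3 remains open. So does the outcome for a longer chain or a naphthalen-1-yl group at this carbon.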